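A Second Fluoro Where Three Compounds Sit at the Limit

The source may report more compounds than this note shows. Statements on the series, on what has been measured and on what is new or still open speak of the compounds shown alone.

Three compounds share one core, and in a functional assay on MCF7 cells (Homo sapiens) for antiproliferative activity, read by MTT assay, with a stated time of 72 h (on this read-out higher numbers stand for weaker inhibition and lower numbers for stronger inhibition), none of them gives a number. Compound 1 `O=C(COc1ccc(C(=O)/C=C/c2ccccc2)cc1)N[C@H]1CCOC1=O` reaches only the limit > 64000 nM in this assay. Compound 2 `O=C(COc1ccc(C(=O)/C=C/c2cccc([N+](=O)[O-])c2)cc1)N[C@H]1CCOC1=O` likewise stops at the limit > 64000 nM in this assay. Compound 3 `O=C(COc1ccc(C(=O)/C=C/c2ccc(F)cc2)cc1)N[C@H]1CCOC1=O` also stands at the limit > 64000 nM in this assay, so its place on the numbers is known only as a limit. The steps a step that the two limits leave unreadable from compound 1 to compound 2, a step that the two limits leave unreadable from compound 1 to compound 3 and a step that the two limits leave unreadable from compound 2 to compound 3 carry no readable size, because of the limit of > 64000 nM in this assay, at which 3 of the 3 values shown sit. Compound 4 `O=C(COc1ccc(C(=O)/C=C/c2ccc(F)c(F)c2)cc1)N[C@H]1CCOC1=O` differs from compound 3 by fluoro in place of hydrogen on an aromatic carbon. Going by the values given here, the one measured step of the same kind, fluoro in place of hydrogen on an aromatic carbon, is unreadable, so no measured step gives a direction, and nothing in the three values suggests that compound 4 should enter the measurable range of this assay. Compound 4 is therefore expected to remain at the limit, with an estimated value of 100000 nM, between 40000 nM and 300000 nM. The step this estimate means, a step that the limit leaves unreadable from compound 3 to compound 4, is expected to be none beyond the scatter.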

Compound 4, half-maximal inhibitory concentration: > 64000 nM
Compound 4 gave a limit, no number; the forecaster's own chance of this, stated with the estimate: 85%; the middle value is on the limit's open side.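

In this assay compound 4 joins compound 1, compound 2 and compound 3 without a number, so no step among these four compounds can be read, because all of them stop at one limit: the limit of > 64000 nM in this assay, at which 4 of the 4 values shown sit.

What the compounds shown leave open is how far apart they lie in this assay, and whether any change to the shared core would give a number there.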